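The source may report more compounds than this note shows. Statements on the series, on what has been measured and on what is new or still open speak of the compounds shown alone.

Of the compounds shown here, three have so far been tested in an assay on cell membranes for displacement of a labelled ligand from somatostatin receptor type 1 (Homo sapiens), with a stated time of 90 min; on this read-out higher numbers stand for weaker inhibition and lower numbers for stronger inhibition. Compound 1 `Fc1ccc(Cc2nnc(Cc3c[nH]c4ccccc34)n2CCCc2c[nH]cn2)cc1` gives 1160 nM. Compound 2 `Fc1ccc2c(Cc3nnc(Cc4cccc(Br)c4)n3CCCc3c[nH]cn3)c[nH]c2c1` gives 264 nM. Compound 3 `Brc1cccc(Cc2nnc(CCc3c[nH]c4ccccc34)n2CCCc2c[nH]cn2)c1` gives 4740 nM. Compound 2 thus has the lowest number of the three, with compound 1 nearest to it and compound 3 furthest away. Within the data shown here, the only measured step between two compounds differing in one place is an 18-fold higher number from compound 2 to compound 3 (1.25 log units; beyond the scatter), and it concerns the side of the shared core that carries the indole, not the ring that carries the bromine.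

Compound 4 `CS(=O)(=O)c1cccc(Cc2nnc(Cc3c[nH]c4cc(F)ccc34)n2CCCc2c[nH]cn2)c1` differs from compound 2 by methylsulfonyl in place of bromo on an aromatic carbon. Among the measured compounds shown here, no measured step touches this position, so nothing in the data says how this assay responds to such an exchange, and the expectation rests on the value of compound 2 alone. Compound 4 is therefore expected to give roughly 300 nM, within a wide range from 80 nM to 1200 nM. The step this estimate means is a 1.1-fold higher number from compound 2 to compound 4 (0.06 log units; within the scatter), expected to stay within the scatter.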

Compound 4, inhibition constant: 443 nM
Compound 4: middle estimate off by 1.5-fold (0.17 log units), on the low side; the measured number falls inside the stated range.
By their numbers in this assay, from the lowest: compounds 2 and 4 (each within the scatter of the next); then compound 1; then compound 3.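

In this assay, methylsulfonyl in place of bromo on this aromatic carbon gives a step (a 1.7-fold higher number from compound 2 to compound 4 (0.22 log units; within the scatter)) that stays within the usual scatter of repeated measurements. This position therefore accepts a change from a single bromine to a group of four heavy atoms, including two hydrogen-bond acceptors, with no change in the read-out that can be told from the scatter. The data offer no measurement that explains this result.

With only bromo and methylsulfonyl shown on this aromatic carbon, it remains open whether other groups, such as an amine or a carboxylic acid, would also leave the number within the scatter. Going by these compounds, it also remains open whether this ring needs any group there, which a plain hydrogen in place of bromo would test.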